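Labdane acids without a readable cytotoxic signal

A few compounds are considered here, and "the series" means these few. Any claim that something is new, unique, unknown or untested is made for them only; others in the source may bear on it.

Compound 3 `C=C1CC[C@@H]2[C@](C)(CCC[C@]2(C)C(=O)O)[C@H]1C/C=C(\C)C=O` sits at a limit rather than a number. In a functional assay on A549 cells (Homo sapiens) for cytotoxicity, read by MTT assay, with a stated time of 48 h (on this read-out higher numbers stand for weaker inhibition and lower numbers for stronger inhibition), compound 3 gives > 40000 nM, which is a limit of the assay. Its two neighbours tell the same story. Compound 1 `C=C1CC[C@@H]2[C@](C)(CCC[C@]2(C)C(=O)O)[C@H]1CC/C(C)=C/CO` gives > 40000 nM in this assay, again a limit. Compound 2 `C=C[C@@]1(C)O[C@H]1C[C@H]1C(=C)CC[C@@H]2[C@]1(C)CCC[C@]2(C)C(=O)O` gives > 40000 nM in this assay, also a limit. The three steps that join them, a step that the two limits leave unreadable from compound 1 to compound 2, a step that the two limits leave unreadable from compound 1 to compound 3 and a step that the two limits leave unreadable from compound 2 to compound 3, are therefore unreadable, as the limit of > 40000 nM in this assay, at which 3 of the 3 values shown sit, records. Compound 4 `C=CC(=C)[C@H](O)C[C@H]1C(=C)CC[C@@H]2[C@]1(C)CCC[C@]2(C)C(=O)O` differs from compound 3 by a group of 6 heavy atoms (5 carbon, 1 oxygen; no ring) in place of a group of 5 heavy atoms (4 carbon, 1 oxygen; no ring), on a saturated chain carbon bound to a saturated ring carbon. No measured step bears on this change in a readable way, and nothing in the shared core has yet shown a value below the limit. Compound 4 is therefore expected to remain near the limit, with the step that the limit leaves unreadable from compound 3 to compound 4 expected to be no larger than the scatter. The estimate for compound 4 in this assay is 60000 nM, with a range from 20000 nM to 200000 nM, and the assay is most likely to report only a limit again.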

Compound 4, half-maximal inhibitory concentration: > 40000 nM
Compound 4: a limit, no number; the forecaster's own chance of this, stated with the estimate: 75%; the middle value does not contradict the limit.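

Compound 4 adds no readable step to compound 1, compound 2 or compound 3, as all four stand at a limit and not at a number: the limit of > 40000 nM in this assay, at which 4 of the 4 values shown sit. The compounds shown leave open whether any group on this saturated chain carbon gives a readable value in this assay.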